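A few compounds are considered here, and "the series" means these few. Any claim that something is new, unique, unknown or untested is made for them only; others in the source may bear on it.

All of the numbers below come from a functional assay on MDA-MB-231 cells (Homo sapiens) for antiproliferative activity, read by MTT assay; a lower number here means a stronger inhibitor, a higher number a weaker inhibitor.

Compound 1, `CC/C=C\C/C=C\C/C=C\CCCCCCCC1(O)CC(=O)c2c(O)cc(OCOC)cc2O1`, gives 6790 nM.
Compound 2, `CCCCC/C=C\C/C=C\CCCCCCCC1(O)CC(=O)c2c(O)cc(OCOC)cc2O1`, gives 16100 nM.
Compound 3, `CCCCC/C=C\C/C=C\CCCCCCCc1cc(=O)c2c(O)c(C)c(OCOC)cc2o1`, reaches only a limit of the assay, > 87000 nM.

Compounds 1 and 2 share one core and differ in a single place: but-1-en-1-yl in place of butyl on a saturated chain carbon bound to a double-bonded chain carbon. That change produces a 2.4-fold lower number from compound 2 to compound 1 (0.37 log units; beyond the scatter), a step that lies beyond the usual scatter of the measurement. Compound 3 is built on a different core, and the difference between the two cores is not broken down here. The result for compound 3 is a limit rather than a number; the assay reports (the limit of > 87000 nM in this assay, at which 1 of the 3 values shown sits).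

Compound 4, `CC/C=C\C/C=C\C/C=C\CCCCCCCc1cc(=O)c2c(O)c(C)c(OCOC)cc2o1`, has not yet been measured. It differs from compound 3 by the same change that separates compound 2 from compound 1: but-1-en-1-yl in place of butyl on a saturated chain carbon bound to a double-bonded chain carbon. The place of the change is described in the same words in both pairs, so the same change is being made on a second core. Because the earlier pair showed a 2.4-fold lower number from compound 2 to compound 1 (0.37 log units; beyond the scatter), a step of similar direction and modest size is expected from compound 3 to compound 4, as an at least 1.4-fold lower number from compound 3 to compound 4 (0.16 log units; that floor lies within the scatter). That expectation rests on a single measured pair, and on a starting point that is itself only a limit, so it is loosely held. Compound 4 is therefore expected to come in near 60000 nM, with a plausible range from 20000 nM to 150000 nM, and a real chance that the assay once more reports only a limit.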

Compound 4, half-maximal inhibitory concentration: 6790 nM
Compound 4: the middle estimate sits 8.8-fold (0.95 log units) above what was measured; the measured number lies below the stated range.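

In this assay, the same change, but-1-en-1-yl in place of butyl on a saturated chain carbon bound to a double-bonded chain carbon, gives an at least 12-fold lower number from compound 3 to compound 4 (1.10 log units; beyond the scatter), against a 2.4-fold lower number from compound 2 to compound 1 (0.37 log units; beyond the scatter) on the first core. Both steps point the same way, so the direction of the change carries from one core to the other in these two pairs, but its size does not, and the gap between the steps is larger than repeat measurements would explain: the same change on two cores in this assay, a 2.4-fold lower number (0.37 log units; beyond the scatter) from compound 2 to compound 1 and an at least 12-fold lower number (1.10 log units; beyond the scatter) from compound 3 to compound 4, at least 5.4-fold (0.73 log units) apart, beyond the scatter of two such steps Compound 3 gives > 87000 nM, which is a limit of the assay and not a number, so the data show only the smallest size the new step can have, not its true size, and two pairs cannot establish a rule for the whole series.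

The two cores differ, and the compounds shown do not reveal which part of that difference goes with the larger step, or whether a third core would behave like either of these two. On these data alone, it also remains open whether a longer chain, or a chain carrying an amine or a carboxylic acid, would change the number in this assay on either core.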